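Side-chain change from compound 2 to compound 3

The source may report more compounds than this note shows. Statements on the series, on what has been measured and on what is new or still open speak of the compounds shown alone.

Compound 2 `C/C(=N\OCCCCO)c1ccc(Cl)cc1` stands at a limit in a functional assay on the whole organism for inhibition, with Rattus norvegicus as the target, read by paw edema, with stated times of 1 h and 3 h, at a dose of 50 mg/kg by the oral route; a higher number here means more inhibition at the dose given (going by the name of the read-out), a lower number less inhibition: compound 2 gives < 20%, which is a limit of the assay and not a number. For the measured compounds named here, compound 1 `C/C(=N\OCC(=O)O)c1cccc2ccccc12` is the only other member with a reading, and in this assay compound 1 gives 20%. Of the two values shown, (the limit of < 20% in this assay, at which 1 of the 2 values shown sits), so the two compounds cannot be placed in order against each other. Compound 3 `C/C(=N\OCC(C)O)c1ccc(Cl)cc1` has not yet been measured. The change is 1-hydroxyethyl in place of 3-hydroxypropyl on a saturated chain carbon bound to an oxygen. Going by the values given here, no step between measured compounds is available, so the size of this step cannot be read off from the data. The expected step that the limit leaves unreadable from compound 2 to compound 3 is none beyond the scatter. There is a fair chance that compound 3 again comes back only as a limit. Compound 3 is expected to give about 15% in this assay, within 3% to 30%.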

Compound 3, a percentage reported as inhibition, in the whole organism at one dose (the size of the read-out at that dose, not a potency): < 20%
Compound 3 ended at the assay's limit; the forecaster's own chance of this, stated with the estimate: 60%; the middle value lies beyond the limit too.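

In this assay compound 2 gives < 20%, a limit of the assay and not a number. For the compounds shown here, compound 3 gives < 20%, also a limit, so no step between compound 2 and compound 3 can be read. The compounds shown leave open how the 3-hydroxypropyl and 1-hydroxyethyl side chains compare in this assay.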